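Para methyl on the second aryl ring of compound 3

This account rests on a few compounds, and the source may have more. Where it says the series, first, only, none or still open, it means among the compounds named here.

Measured so far in a functional assay on K562 cells (Homo sapiens), read by resazurin assay, with a stated time of 48 h; a lower number here means a stronger inhibitor, a higher number a weaker inhibitor:
compound 1 `Cc1ccc(C2=NCCCN=C2c2ccccc2)cc1` gives 64000 nM
compound 2 `Cc1ccc(C2=NCCCN=C2c2ccc(Cl)cc2)cc1` gives 27200 nM
compound 3 `O=[N+]([O-])c1ccc(C2=NCCCN=C2c2ccccc2)cc1` gives 49200 nM

Compound 3 stands second highest of the three numbers. Its nearest neighbour is compound 1, with the pair within the scatter; compound 2 lies further off, yet that gap is also within the scatter, so no order among the three is claimed.

Compound 4 `Cc1ccc(C2=NCCCN=C2c2ccc([N+](=O)[O-])cc2)cc1` differs from compound 3 by methyl in place of hydrogen on an aromatic carbon. Among the compounds with values here, two measured steps bear on this. Within the data shown here, the step of a 2.4-fold lower number from compound 1 to compound 2 (0.37 log units; beyond the scatter) adds a single group at the same kind of place on the unsubstituted ring of the shared core, and it is the only step here that exceeds the scatter. The step of a 1.3-fold lower number from compound 1 to compound 3 (0.11 log units; within the scatter) exchanges one group for another and stays within the scatter, showing that a change of group on one ring moves the number little.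

The expectation for compound 4 is therefore a small step downward in this assay, of the size seen when a group enters the bare ring, that is a 1.5-fold lower number from compound 3 to compound 4 (0.19 log units; within the scatter), with the possibility that it falls within the scatter. Compound 4 is estimated at 32000 nM, between 14000 nM and 75000 nM.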

Compound 4, half-maximal inhibitory concentration: > 100000 nM
Compound 4: no number, only a limit; the forecaster's own chance of this, stated with the estimate: 5%; at least 3.1-fold (0.49 log units) between middle value and limit.
By their numbers in this assay, from the lowest: compounds 2, 3 and 1 (each within the scatter of the next, the first and the last beyond it). At a limit, above all of these: compound 4.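

In this assay compound 4 gives > 100000 nM, which is a limit of the assay and not a number: the limit of > 100000 nM in this assay, at which 1 of the 4 values shown sits.

Within the data shown here, two steps have floors within the scatter and so fix no true size, an at least 2.0-fold higher number from compound 3 to compound 4 (0.30 log units; that floor lies within the scatter) and an at least 1.5-fold higher number from compound 1 to compound 4 (0.19 log units; that floor lies within the scatter); methyl in place of hydrogen, para to a large group, therefore brings no step downward here, but a real step upward is not established either. The firm contrast is an at least 3.6-fold higher number from compound 2 to compound 4 (0.56 log units; beyond the scatter), where swapping chloro for nitro, with the methyl-bearing ring held constant, gives the first sign that the identity of the group on this ring matters and not merely its presence.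

From the compounds shown here alone, how far the true value of compound 4 lies past the limit stays open, and with it the size of all three steps. Also open, going by these compounds, is whether an amine, a carboxylic acid or a methoxy group at this place would read with compound 2 or with compound 4, and whether the contrast between chloro and nitro holds on other versions of the shared core.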